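Lengthening the Alkenyl Chain: From Compound 3 to Compound 4

This account rests on a few compounds, and the source may have more. Where it says the series, first, only, none or still open, it means among the compounds named here.

Of the compounds shown here, three built on a shared core have been measured in a functional assay on the whole organism (Abdomen, strain Swiss) for inhibition, with Mus musculus as the target, with stated times of 30 min, 10 min and 5 min, at a dose of 10 mg/kg by the oral route; on this read-out lower numbers stand for a weaker effect and higher numbers for a stronger effect at the one dose given. Compound 1 `CCC(=O)c1c(C)nn(CCCN2CCN(c3ccc(C)cc3)CC2)c(=O)c1N` gives 9%. Compound 2 `CCCCC(=O)c1c(C)nn(CCCN2CCN(c3ccc(C)cc3)CC2)c(=O)c1N` gives 8% in this assay. Compound 3 `CC/C=C/c1c(C)nn(CCCN2CCN(c3ccc(C)cc3)CC2)c(=O)c1N` gives 5% in this assay. Compound 3 thus carries the smallest of the three numbers, yet the gaps to the other two, a number 4 percentage points lower from compound 1 to compound 3 (within the scatter) and a number 3 percentage points lower from compound 2 to compound 3 (within the scatter), both lie within the scatter, so the three compounds cannot be told apart on this read-out.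

Compound 4 `CCC/C=C/c1c(C)nn(CCCN2CCN(c3ccc(C)cc3)CC2)c(=O)c1N` has not yet been measured. It differs from compound 3 by methyl in place of hydrogen on a saturated chain carbon, two bonds along the chain from a double-bonded chain carbon. Among the compounds with values here, the closest precedent among the measured steps is the chain extension from compound 1 to compound 2, in which a number 1 percentage points lower from compound 1 to compound 2 (within the scatter); that step also added carbons to a saturated chain, there two bonds along from a carbonyl carbon. The other two steps exchanged the whole group on the aromatic carbon and likewise stayed within the scatter. On this basis no step beyond the scatter is expected for compound 4 in this assay, the expected step being no change at the digits printed from compound 3 to compound 4 (within the scatter). Compound 4 is therefore estimated at 5%, with a range from 0% to 14%.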

Compound 4, a percentage reported as inhibition, in the whole organism at one dose (the size of the read-out at that dose, not a potency): 0%
The estimate for compound 4 lay 5 percentage points above the measured number; low and high end bracket the measured number.
By their numbers in this assay, from the lowest: compounds 4, 3, 2 and 1 (each within the scatter of the next).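

In this assay, within the data shown here, methyl in place of hydrogen on a saturated chain carbon, two bonds along the chain from a double-bonded chain carbon, leaves a number 5 percentage points lower from compound 3 to compound 4 (within the scatter) and so shows that this change to the alkenyl chain, like the earlier extension next to no double bond, gives no step that stands out from the scatter. Exchanging the group on the aromatic carbon with the longer alkenyl chain in place adds two further readings, with pent-1-en-1-yl in place of butylcarbonyl leaving a number 8 percentage points lower from compound 2 to compound 4 (within the scatter) and pent-1-en-1-yl in place of propanoyl leaving a number 9 percentage points lower from compound 1 to compound 4 (within the scatter) and neither separating the compounds, so the four cannot be told apart on this read-out at the one dose given. Nothing measured here offers an explanation for these numbers.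

On these data alone, whether a hexenyl chain, a saturated pentyl chain or a carboxylic acid on that aromatic carbon would rise clear of the scatter stays open. Also open is whether any of these compounds would show a larger effect at another dose, since a single dose gives the size of the effect and not a potency.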